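The source may report more compounds than this note shows. Statements on the series, on what has been measured and on what is new or still open speak of the compounds shown alone.

Four compounds are considered here. Compound 1 `CCOC(=O)c1c(-c2cccc(-c3ccccc3)c2)[nH]c2cc(Cl)c(OC)cc2c1=O` carries a phenyl group; compound 2 `CCOC(=O)c1c(-c2cccc(OC)c2)[nH]c2cc(Cl)c(OC)cc2c1=O` carries a methoxy in its place, the change being (methoxy in place of phenyl on an aromatic carbon). Compound 3 `CCOC(=O)c1c(-c2cccc(-c3ccccc3)c2)[nH]c2cc(OC)c(Cl)cc2c1=O` has the same atoms as compound 1 joined differently; the difference between the two cores is not broken down here. Compound 4 `CCOC(=O)c1c(-c2cccc(OC)c2)[nH]c2cc(OC)c(Cl)cc2c1=O` stands to compound 3 as compound 2 stands to compound 1, by the same change, (methoxy in place of phenyl on an aromatic carbon).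

In an ADME assay on HepG2 cells (Homo sapiens) for cytotoxicity, read by luminescence, with a stated time of 72 h (a higher number here means that more compound is needed for the effect, a lower number that less compound is needed), compound 1 gives only a limit, > 21500 nM. Compound 2 likewise gives only a limit, > 21500 nM. Compound 3 also reaches only a limit, > 21500 nM. The measured step that the two limits leave unreadable from compound 1 to compound 2 therefore cannot be sized, because the limit of > 21500 nM in this assay, at which 3 of the 3 values shown sit, is where all three values sit. For compound 4 the step that the limit leaves unreadable from compound 3 to compound 4 is expected to be just as unreadable, since the same change is made on a core that also stopped at the limit. Compound 4 is expected to give about 30000 nM in this assay, most likely once more only as a limit rather than a number.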

Compound 4, half-maximal effective concentration: > 21500 nM
Compound 4: a limit, no number (the forecaster's own chance of this, stated with the estimate: 90%); the middle value lies beyond the limit too.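

Compound 3 and compound 4 each give only a limit rather than a number, so no new step can be read between them: the limit of > 21500 nM in this assay, at which 4 of the 4 values shown sit.

The compounds shown leave open what number any of the four would reach in this assay, and whether putting methoxy in place of phenyl changes it at all.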